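Naphthalen-1-yl in place of 4-methoxyphenyl: an expected value

The source may report more compounds than this note shows. Statements on the series, on what has been measured and on what is new or still open speak of the compounds shown alone.

Measured compounds:
compound 1 `Brc1cn2ccnc2c(-c2ccc3ncn(C4CCCCC4)c3c2)n1` — 18%
compound 2 `COc1ccc(-c2cn3ccnc3c(-c3ccc4ncn(C5CCCCC5)c4c3)n2)cc1` — 92%

In a functional assay on K562 cells (Homo sapiens) for inhibition, read by sulforhodamine B assay, with a stated time of 48 h, tested at 10 uM (a lower number here means less inhibition, a higher number more inhibition at the concentration tested (going by the name of the read-out)), compound 2 gives 92%, the highest of the two numbers. Compound 1 gives 18%, and the step of a number 74 percentage points higher from compound 1 to compound 2 (beyond the scatter) is large. Compound 3 `c1ccc2c(-c3cn4ccnc4c(-c4ccc5ncn(C6CCCCC6)c5c4)n3)cccc2c1` differs from compound 2 by naphthalen-1-yl in place of 4-methoxyphenyl on an aromatic carbon. For the measured compounds named here, the one measured step bears only partly on this change, since it replaces bromo with an aryl group, and no step between two aryl groups is known. Because a number 74 percentage points higher from compound 1 to compound 2 (beyond the scatter) was large when an aryl group entered, compound 3, which keeps an aryl group, is expected to remain high. The step of a number 10 percentage points lower from compound 2 to compound 3 (within the scatter) is therefore expected to be small, likely within the scatter. The estimate for compound 3 is 82%, between 50% and 100%.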

Compound 3, a percentage reported as inhibition, at one concentration (the size of the read-out at that concentration, not a potency): 30.9%
For compound 3 the middle estimate is 51.1 percentage points above the measured one; measured number outside the range, below it.
By their numbers in this assay, from the lowest: compound 1; then compound 3; then compound 2.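

In this assay this position on the shared core responds to which aryl group it carries, not merely to the presence of one: naphthalen-1-yl in place of 4-methoxyphenyl gives a number 61.1 percentage points lower from compound 2 to compound 3 (beyond the scatter) as the step. Against bromo, naphthalen-1-yl brings only a number 12.9 percentage points higher from compound 1 to compound 3 (beyond the scatter) and so does not repeat the large gain seen with 4-methoxyphenyl. Nothing available explains this difference between the two aryl groups.

The compounds shown leave open whether plain phenyl, or a phenyl carrying an amine or a carboxylic acid, would behave like 4-methoxyphenyl. They also leave open how naphthalen-2-yl would compare with naphthalen-1-yl.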